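Homologation step repeated on a second core

The source may report more compounds than this note shows. Statements on the series, on what has been measured and on what is new or still open speak of the compounds shown alone.

Compound 1 `CCCCCCCCCCn1cc(-c2nc3ccccc3cc2C)nn1` and compound 2 `CCCCCCCCCCn1cc(-c2nc3ccccc3cc2CC)nn1` differ by methyl in place of hydrogen on a saturated chain carbon bound to an aromatic carbon. In a functional assay on U-937 cells (Homo sapiens) for cytotoxicity, read by MTT assay, with a stated time of 24 h (on this read-out higher numbers stand for weaker inhibition and lower numbers for stronger inhibition), compound 1 returns only a limit, > 100 ug/mL. Compound 2 gives 12.7 ug/mL in this assay. The step is an at least 7.8-fold lower number from compound 1 to compound 2 (0.89 log units; beyond the scatter). It starts from a limit, and only its lower bound is known. Compound 3 `CCc1cc2ccccc2nc1-c1cn(-c2ccc(F)cc2)nn1` carries another core; the difference between the cores of compound 1 and compound 3 is not broken down here. In this assay compound 3 returns only a limit, > 100 ug/mL. Compound 4 `CCCc1cc2ccccc2nc1-c1cn(-c2ccc(F)cc2)nn1` is not yet measured and differs from compound 3 by methyl in place of hydrogen on a saturated chain carbon, two bonds along the chain from an aromatic carbon. This is the same kind of change as from compound 1 to compound 2, but the place differs: there the entering methyl sits on a saturated chain carbon bound to an aromatic carbon, here on a saturated chain carbon two bonds along the chain from an aromatic carbon. The expected step of an at least 2.0-fold lower number from compound 3 to compound 4 (0.30 log units; that floor lies within the scatter) is set smaller than an at least 7.8-fold lower number from compound 1 to compound 2 (0.89 log units; beyond the scatter) because compound 3 starts at the limit of > 100 ug/mL in this assay, at which 2 of the 3 values shown sit, and the earlier step is known only as a bound. Compound 4 is expected to give about 50 ug/mL, likely between 15 ug/mL and 150 ug/mL, with a real chance that only a limit is returned again.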

Compound 4, half-maximal inhibitory concentration: 67.4 ug/mL
Beside the measured number, compound 4's estimate is 1.3-fold (0.13 log units) below it; the measured number falls inside the stated range.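

Carried to the core of compound 3, the change gives a step known only as a floor, an at least 1.4-fold lower number from compound 3 to compound 4 (0.17 log units; that floor lies within the scatter), so a real shift on this core is not established. Compound 3 returns only a limit in this assay, > 100 ug/mL, and the true size of the step stays unknown: the limit of > 100 ug/mL in this assay, at which 2 of the 4 values shown sit.
The comparison with the first core shows that the change has been read on both cores, but not that it carries over with the same size or a different one, and the entering methyl also sits at a different place on each: the same change on two cores in this assay, an at least 7.8-fold lower number (0.89 log units; beyond the scatter) from compound 1 to compound 2 and an at least 1.4-fold lower number (0.17 log units; that floor lies within the scatter) from compound 3 to compound 4; the limit leaves it open whether they differ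

Open, on these data alone, is whether ethyl to propyl on the core of compound 1 would match the step on the core of compound 3, which would set the same change at the same place on both cores. Also open, as far as these compounds go, is how a longer chain, or an amine or a carboxylic acid at the end of the chain, would read in this assay on either core.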